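Undefined Ring Stereochemistry: From Compound 1 to Compound 3

This account rests on a few compounds, and the source may have more. Where it says the series, first, only, none or still open, it means among the compounds named here.

Compound 1 `CN(C)CC[C@H]1CCC[C@@H](c2ccccc2)C1` has two stereocentres on its saturated ring, both drawn with a fixed configuration. Among the compounds with values here, in an assay on membranes from liver for displacement of a labelled ligand from Sigma intracellular receptor 2 (Rattus norvegicus), read by scintillation counting, with a stated time of 120 min (on this read-out lower numbers stand for stronger inhibition and higher numbers for weaker inhibition), compound 1 gives 156 nM, the only firm number it has there; a further entry for it carries no single number. A related compound 2 `c1ccc(CNCC[C@@H]2CCC[C@@H](c3ccccc3)C2)cc1` has two entries in this assay, 268 nM; 57 nM (2 entries), and the several entries of compound 2 in this assay, 268 nM; 57 nM (2 entries) shows how far repeats of one compound can spread, which sets the frame for reading any single value.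

Compound 3 `CN(C)CCC1CCCC(c2ccccc2)C1` has not been measured. Its difference from compound 1 is the two compounds have the same atoms and bonds; at least one stereo element is drawn with a configuration in one of them and without one in the other: 2 of 2 stereo elements differ; a stereocentre at a saturated ring carbon is drawn S in compound 1 and without a configuration in compound 3; a stereocentre at a saturated ring carbon is drawn R in compound 1 and without a configuration in compound 3, so the atoms and bonds are identical and only the drawn configuration at the two ring carbons is left open. Within the data shown here, no measured pair is available to calibrate such a change. The expected step from compound 1 to compound 3 in this assay is a 1.4-fold higher number from compound 1 to compound 3 (0.15 log units; within the scatter), a small move toward weaker binding, or none beyond the scatter. Compound 3 is therefore estimated at 220 nM, with a range from 80 nM to 600 nM.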

Compound 3, inhibition constant: 115 nM
Compound 3: middle estimate off by 1.9-fold (0.28 log units), on the high side, within the range that was stated.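

In this assay, leaving the configuration open at the two ring carbons gives a 1.4-fold lower number from compound 1 to compound 3 (0.13 log units; within the scatter), so on this read-out the drawn form and the undrawn form cannot be told apart. This is the first measured step of this kind in the series, and it offers no sign that fixing the two ring carbons as drawn in compound 1 changes the number, though what it can say about configuration is limited by a plain fact of the comparison: the fact that one of compounds 1 and 3 is drawn with a defined configuration and the other without, at the place where they differ. A small gap also has to be read against how far repeats of a single compound can lie apart here: the several entries of compound 2 in this assay, 268 nM; 57 nM (2 entries).

From the compounds shown here alone, how each other configuration at the two ring carbons would read on its own remains open, and a single pair cannot show whether the same small step would hold for other compounds with this shared core. Also open, going by these compounds, is what a hydroxyl group on the shared core, or a longer chain leading to the amine, would do to the number in this assay.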